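Phenyl in place of cyano: an expected rise

This account rests on a few compounds, and the source may have more. Where it says the series, first, only, none or still open, it means among the compounds named here.

Compound 1 `CC(/N=c1\c(O)c(O)\c1=N/c1cccc2cccnc12)C(C)(C)C`: 8100 nM
Compound 2 `CC(/N=c1\c(O)c(O)\c1=N/c1ccc(OC(F)(F)F)cc1)C(C)(C)C`: > 30000 nM (a limit of the assay)
Compound 3 `CC(/N=c1\c(O)c(O)\c1=N/c1ccc(C#N)cc1)C(C)(C)C`: 520 nM

In a functional assay for inhibition, with Rattus norvegicus as the target (a lower number here means a stronger inhibitor, a higher number a weaker inhibitor), compound 3 gives 520 nM and holds the lowest number shown. Compound 1 gives 8100 nM and lies above it, beyond the scatter. Compound 2 gives > 30000 nM only as a limit of the assay.

Compound 4 `CC(/N=c1\c(O)c(O)\c1=N/c1ccc(-c2ccccc2)cc1)C(C)(C)C` carries phenyl in place of cyano on an aromatic carbon. For the measured compounds named here, one measured step bears on this place, the large change an at least 57-fold lower number from compound 2 to compound 3 (1.76 log units; beyond the scatter) with cyano in place of trifluoromethoxy. Read in reverse, this step suggests that losing the cyano can cost a great deal, so a large move to a higher number is expected rather than none beyond the scatter. From the compounds shown here alone, it is a single step, and phenyl itself remains untested there. The estimate means an expected change a 17-fold higher number from compound 3 to compound 4 (1.24 log units; beyond the scatter) in this assay on this reading. Compound 4 is expected near 9000 nM with an estimated range from 1800 nM to 40000 nM in that assay.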

Compound 4, half-maximal inhibitory concentration: > 30000 nM
Compound 4: only a limit was reported (the forecaster's own chance of this, stated with the estimate: 35%); middle value at least 3.3-fold (0.52 log units) from the limit.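

In this assay, phenyl in place of cyano gives an at least 57-fold higher number from compound 3 to compound 4 (1.76 log units; beyond the scatter), so a second replacement at this place, on an aromatic carbon para to a large group, also ends far from the number of the cyano compound. For compound 4, the value > 30000 nM is a limit of the assay. The step between compound 2 and compound 4 cannot be read, and trifluoromethoxy and phenyl cannot be ordered at this place, because both values stop at the same limit: the limit of > 30000 nM in this assay, at which 2 of the 4 values shown sit.

From the compounds shown here alone, whether a small group such as chloro, or an amine or a carboxylic acid, would keep a number near that of compound 3 at this place stays open. The rest of the shared core is the same in compound 2, compound 3 and compound 4, so its part in these numbers is open too.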